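The source may report more compounds than this note shows. Statements on the series, on what has been measured and on what is new or still open speak of the compounds shown alone.

Of the compounds shown here, two that share one core have so far been measured in an ADME assay on a cell-free system (serum) for metabolic stability; a higher number here means that the compound lasts longer, a lower number that the compound disappears faster: compound 1 `CC(C)(C)c1cc(OC(=O)/C=C/c2ccccc2)ccc1O` and compound 2 `CC(C)(C)c1cc(OC(=O)c2ccco2)ccc1O`. Compound 1 gives < 0.25 h, which is a limit of the assay and not a number. Compound 2 gives < 0.25 h, which is also a limit. Compound 2 therefore stands at the limit of < 0.25 h in this assay, at which 2 of the 2 values shown sit, so neither compound has a true half-life to compare.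

Compound 3 `Cc1ccc(C(=O)Oc2ccc(O)c(C(C)(C)C)c2)cc1` keeps the shared core. From compound 2 to compound 3, 4-methylphenyl comes in place of furan-2-yl on a carbonyl carbon (4-methylphenyl in place of furan-2-yl on a carbonyl carbon). Among the compounds with values here, no measured pair yet shows what such a swap does in this assay, so no change beyond the usual scatter is expected. The estimated change is a step that the limit leaves unreadable from compound 2 to compound 3. For compound 3 the estimated half-life is 0.2 h, with an expected range from 0.08 h to 0.6 h.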

Compound 3, half-life: < 0.25 h
Compound 3 ended at the assay's limit (the forecaster's own chance of this, stated with the estimate: 70%); the middle value lies beyond the limit too.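

Compound 2 and compound 3 both give a limit and not a number, so the step between them cannot be read: the limit of < 0.25 h in this assay, at which 3 of the 3 values shown sit.

The compounds shown leave open how long any of them truly lasts in this assay and whether 4-methylphenyl in place of furan-2-yl on a carbonyl carbon changes the half-life at all.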